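Compound 3 to compound 4: cyano replaced by methyl

This account rests on a few compounds, and the source may have more. Where it says the series, first, only, none or still open, it means among the compounds named here.

Measured in an ADME assay on MT4 cells (Homo sapiens) for cytotoxicity, read by MTT assay, with a stated time of 5 days; a lower number here means that less compound is tolerated, a higher number that more compound is tolerated:
- compound 1 `COc1cc2nc([S+]([O-])CC(=O)Nc3ccccc3F)nc(Nc3c(Cl)cc(/C=C/C#N)cc3Cl)c2cc1OC`: > 208000 nM
- compound 2 `COc1cc2nc([S+]([O-])CC(=O)Nc3ccccc3C#N)nc(Nc3c(Cl)cc(/C=C/C#N)cc3Cl)c2cc1OC`: > 206000 nM
- compound 3 `COc1cc2nc([S+]([O-])CC(=O)Nc3ccc(C#N)cc3)nc(Nc3c(Cl)cc(/C=C/C#N)cc3Cl)c2cc1OC`: >= 188000 nM

Compound 3 gives >= 188000 nM, which is a limit and not a number. The results for compound 1 and compound 2 are also limits, so compound 3 has no ranked place in the series.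

Compound 4 `COc1cc2nc([S+]([O-])CC(=O)Nc3ccc(C)cc3)nc(Nc3c(Cl)cc(/C=C/C#N)cc3Cl)c2cc1OC` carries methyl in place of cyano on an aromatic carbon. The closest measured evidence is a step that the two limits leave unreadable from compound 2 to compound 3. The other two comparisons are a step that the two limits leave unreadable from compound 1 to compound 3 and a step that the two limits leave unreadable from compound 1 to compound 2. Among the compounds with values here, none of these has a readable size, and no measured compound carries methyl. No step beyond the scatter is therefore expected in this assay, and no direction can be assigned. The estimated step that the limit leaves unreadable from compound 3 to compound 4 reflects this expectation. Another limit is the most likely report. For compound 4 the estimated value is 190000 nM, with an expected range of 70000 nM to 230000 nM.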

Compound 4, half-maximal cytotoxic concentration: 32200 nM
Compound 4: the middle estimate sits 5.9-fold (0.77 log units) above what was measured; the whole stated range lies above it.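

In this assay compound 4 is the only one of the four shown that gives a number and not a limit, while the steps among compound 1, compound 2 and compound 3 cannot be read. This carbon of the phenyl ring is therefore not indifferent to its substituent: methyl in place of cyano gives an at least 5.8-fold lower number from compound 3 to compound 4 (0.76 log units; beyond the scatter). The comparisons with the two 2-substituted phenyl amides point the same way, with an at least 6.3-fold lower number from compound 2 to compound 4 (0.80 log units; beyond the scatter) and an at least 6.4-fold lower number from compound 1 to compound 4 (0.81 log units; beyond the scatter), although each of these also changes the substituent's place on the ring.

From the compounds shown here alone, the result for compound 3 is a limit, so the full size of the step stays open: the limit of >= 188000 nM in this assay, at which 1 of the 4 values shown sits. Going by these compounds, whether the lower number follows from methyl or from the loss of the nitrile also stays open, and an amine or a longer alkyl chain in the same place would bear on that.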